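A few compounds are considered here, and "the series" means these few. Any claim that something is new, unique, unknown or untested is made for them only; others in the source may bear on it.

Measured in an ADME assay on MT4 cells (Homo sapiens) for cytotoxicity; on this read-out lower numbers stand for higher toxicity in this test and higher numbers for lower toxicity in this test:
Compound 1 `O=C(NC(=S)Nc1cccc(C(F)(F)F)c1)c1ccccc1`: > 100000 nM
Compound 2 `Fc1ccc(NC(=S)Nc2cccc(C(F)(F)F)c2)cc1Cl`: 8000 nM

Compound 1 stands at the limit of > 100000 nM in this assay, at which 1 of the 2 values shown sits. That entry is a limit of the assay and not a number, so the true position of compound 1 is not pinned down.

Compound 3 `CC(=O)NC(=S)Nc1cccc(C(F)(F)F)c1` has not been measured yet. It is made from compound 1 by placing methyl in place of phenyl on a carbonyl carbon. The swap removes the ring and leaves the rest of the core of compound 1 unchanged.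

Going by the values given here, no measured step between any two compounds is available as a guide. Compound 2 reads 8000 nM, which shows that a clearly measurable toxicity can occur in this small set. Even so, the change here is confined to one small group, so only a modest shift is expected, either within the scatter or slightly towards higher toxicity. The expected step is an at least 1.2-fold lower number from compound 1 to compound 3 (0.09 log units; that floor lies within the scatter). The estimated value for compound 3 is 80000 nM, with an expected range of 25000 nM to 200000 nM.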

Compound 3, half-maximal cytotoxic concentration: > 100000 nM
Compound 3: no number, only a limit; the forecaster's own chance of this, stated with the estimate: 60%; at least 1.2-fold (0.09 log units) between middle value and limit.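

No step can be read from compound 1 to compound 3 because, in this assay, both entries are limits and not numbers: the limit of > 100000 nM in this assay, at which 2 of the 3 values shown sit. The compounds shown leave open where the true values of compound 1 and compound 3 lie, and whether methyl in place of phenyl on a carbonyl carbon changes this read-out at all.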